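A few compounds are considered here, and "the series" means these few. Any claim that something is new, unique, unknown or untested is made for them only; others in the source may bear on it.

Of the compounds shown here, three built on one shared core have been measured in an in vitro functional assay on cells for agonist activity at Bombesin receptor subtype-3 (Mus musculus), read by luminescence and calcium flux; a higher number here means that more compound is needed for the effect, a lower number that less compound is needed. Compound 1 `O=C(O)c1ccccc1-c1ccc(CCc2ncc(CC3CCC3)[nH]2)cc1` gives 7.1 nM, compound 2 `O=C(O)c1ccccc1-c1ccc(CCc2ncc(Cc3ccc(F)cc3)[nH]2)cc1` gives 50 nM, and compound 3 `CC(C)(C)c1cnc(CCc2ccc(-c3ccccc3C(=O)O)cc2)[nH]1` gives 2750 nM, the highest number of the three. Compound 4 `N#Cc1ccccc1Cc1cnc(CCc2ccc(-c3ccccc3C(=O)O)cc2)[nH]1` differs from compound 3 by 2-cyanobenzyl in place of tert-butyl on an aromatic carbon. Among the compounds with values here, two measured steps bear on this change, both running the opposite way: a 55-fold higher number from compound 2 to compound 3 (1.74 log units; beyond the scatter) and a 390-fold higher number from compound 1 to compound 3 (2.59 log units; beyond the scatter), each a large rise on arriving at tert-butyl. Undoing tert-butyl in favour of a 2-cyanobenzyl group should therefore bring the number down strongly, plausibly toward the region of compound 2, although 2-cyanobenzyl itself has no measured precedent here. Compound 4 is estimated at 60 nM, with a range from 15 nM to 250 nM. That estimate corresponds to an expected step of a 46-fold lower number from compound 3 to compound 4 (1.66 log units; beyond the scatter).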

Compound 4, half-maximal effective concentration: 642 nM
For compound 4 the middle estimate is 11-fold (1.03 log units) below the measured one; measured number above the stated range.
By their numbers in this assay, from the lowest: compound 1; then compound 2; then compound 4; then compound 3.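

Putting an aromatic ring on this carbon does not by itself restore the low numbers: 2-cyanobenzyl in place of tert-butyl brings only a 4.3-fold lower number from compound 3 to compound 4 (0.63 log units; beyond the scatter) and leaves the number well above those of the other two compounds. On the same chain carbon, 2-cyanophenyl falls behind 4-fluorophenyl, with a 13-fold higher number from compound 2 to compound 4 (1.11 log units; beyond the scatter) and it trails cyclobutyl further, with a 90-fold higher number from compound 1 to compound 4 (1.96 log units; beyond the scatter) as the widest gap. From the compounds shown here alone, whether the nitrile itself or its place on the ring accounts for this stays open, as does how unsubstituted benzyl or cyclopentylmethyl would fare. No measurement shown here explains these differences.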